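A Pyrrolidine in Place of an Acetamide Arm

The source may hold more compounds than are shown below. What is called first, only, known or untested is meant among the compounds shown, and "the series" means these compounds.

compound 1 `CN(C)CCN1CCN(c2nc(-c3ccccn3)nc3c2CN(Cc2ccc(F)cc2)CC3)CC1`: "not active" (no number reported)
compound 2 `COc1ccc(CN2CCc3nc(-c4ccccn4)nc(NCCCn4ccnc4)c3C2)cc1`: "not active" (no number reported)
compound 3 `CC(=O)NCCNc1nc(-c2ccccn2)nc2c1CN(Cc1ccc(F)cc1)CC2`: 44.3%

Within the data shown here, in an assay on A549 cells with Cystic fibrosis transmembrane conductance regulator variant F508del (Homo sapiens) as the target, read by fluorescence, with a stated time of 25 min (on this read-out higher numbers stand for larger maximal responses and lower numbers for smaller maximal responses), compound 3 is the only compound with a number; compound 1 gives "not active" (no number reported) and compound 2 gives "not active" (no number reported) in this assay. Compound 4 `Fc1ccc(CN2CCc3nc(-c4ccccn4)nc(NCCN4CCCC4)c3C2)cc1` is not yet measured. It differs from compound 3 in one place: pyrrolidin-1-yl in place of acetamido on a saturated chain carbon, two bonds along the chain from a nitrogen on an aromatic ring. Among the measured compounds shown here, no measured pair shows this same change, so its effect has to be guessed. The step from compound 3 to compound 4 in this assay is expected to be a modest decrease, a number 12.3 percentage points lower from compound 3 to compound 4 (beyond the scatter), somewhat beyond the usual scatter. Compound 4 is therefore estimated to reach 32% in this assay, with a plausible range from 8% to 56%.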

Compound 4, largest response reached (Emax), in percent of the reference or control that the assay uses in the Cystic fibrosis transmembrane conductance regulator assay: 40.6%
For compound 4 the middle estimate is 8.6 percentage points below the measured one; low and high end bracket the measured number.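

In the Cystic fibrosis transmembrane conductance regulator assay there is only a number 3.7 percentage points lower from compound 3 to compound 4 (within the scatter) when pyrrolidin-1-yl replaces acetamido, so this place on the chain accepts a ring without the amide hydrogen and still gives a measurable response. In a physicochemical assay for solubility, read by HPLC, with a stated time of 24 h, at pH 7.4, tested at 250 uM (on this read-out higher numbers stand for higher solubility and lower numbers for lower solubility), compound 3 gives 226000 nM and compound 4 gives 196000 nM and these two values lie within the scatter of each other. No measurement shown here explains why the two groups give such similar results. As far as these compounds go, whether a carboxylic acid or a morpholine ring on the same chain would keep this response in the Cystic fibrosis transmembrane conductance regulator assay stays open. So does the effect of a longer chain carrying the pyrrolidin-1-yl group.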